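A few compounds are considered here, and "the series" means these few. Any claim that something is new, unique, unknown or untested is made for them only; others in the source may bear on it.

In a functional assay on HL-60 cells (Homo sapiens) for antiproliferative activity, read by MTT assay (a higher number here means a weaker inhibitor, a lower number a stronger inhibitor), compound 1 (`CCCC[C@H]1O[C@H](COCc2ccccc2)[C@@H](OCc2ccccc2)[C@H](OCc2ccccc2)[C@H]1O`) is recorded as "not active" (no number reported), and compound 2 (`CC(C)C[C@@H]1O[C@H](COCc2ccccc2)[C@H](OCc2ccccc2)[C@H](OCc2ccccc2)[C@H]1O`) is also recorded as "not active" (no number reported). Among the compounds with values here, compound 3 (`CC(C)(C)C[C@H]1O[C@H](COCc2ccccc2)[C@@H](OCc2ccccc2)[C@H](OCc2ccccc2)[C@H]1O`) gives 12100 nM, the only number available, so it has no measured neighbour to be ranked against. Compound 4 (`CC(C)C[C@H]1O[C@H](COCc2ccccc2)[C@@H](OCc2ccccc2)[C@H](OCc2ccccc2)[C@H]1O`) has yet to be measured. It differs from compound 3 by hydrogen in place of methyl on a saturated chain carbon bound to three saturated chain carbons, which turns tert-butyl into isopropyl and neopentyl into isobutyl. Within the data shown here, no measured step exists to calibrate this change, so the expectation is loose. Among the measured compounds shown here, since the sole number is the 12100 nM of compound 3, and the other two tested compounds gave no number, a small shift towards weaker inhibition is expected, hardly beyond the scatter, and compound 4 may also fail to yield a number. The expected change is a 1.3-fold higher number from compound 3 to compound 4 (0.12 log units; within the scatter). Compound 4 is estimated at 16000 nM, with an expected range of 6000 nM to 45000 nM.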

Compound 4, half-maximal inhibitory concentration: 13900 nM
The estimate for compound 4 lay 1.2-fold (0.06 log units) above the measured number, within the range that was stated.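

In this assay, hydrogen in place of methyl on a saturated chain carbon bound to three saturated chain carbons, which turns neopentyl into isobutyl, gives a 1.1-fold higher number from compound 3 to compound 4 (0.06 log units; within the scatter), so the two compounds cannot be told apart. This gives the series its first measured step and shows that a measurable value does not depend on the neopentyl group, since the isobutyl chain also yields a number. Compound 2 is recorded as "not active" (no number reported) whereas compound 4 gives 13900 nM, so the isobutyl chain alone does not decide whether a number is obtained, and the contrast goes with the drawn configuration: the fact that compounds 2 and 4 differ only in the configuration as drawn.

Still open, as far as these compounds go, is whether a longer chain on this carbon would move the value beyond the scatter. Equally open, from the compounds shown here alone, is what an amine or a carboxylic acid at the end of the chain would do.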